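A Hydroxy Group Where a Bromo Once Helped

A few compounds are considered here, and "the series" means these few. Any claim that something is new, unique, unknown or untested is made for them only; others in the source may bear on it.

Compound 1 `COc1cc(-c2cccc3nc(-c4ccccc4)oc23)cc(OC)c1OC` is the unsubstituted parent; in a functional assay on A549 cells (Homo sapiens) for antiproliferative activity, read by MTT assay, with a stated time of 48 h (on this read-out lower numbers stand for stronger inhibition and higher numbers for weaker inhibition), compound 1 gives 20300 nM, the higher of the two numbers shown. Compound 2 `COc1cc(-c2cccc3nc(-c4cccc(Br)c4)oc23)cc(OC)c1OC` gives 2100 nM. Compound 3 `COc1cc(-c2cccc3nc(-c4ccc(Br)cc4)oc23)cc(OC)c1OC` reaches only the assay limit, > 25000 nM. Compound 4 `COc1cc(-c2cccc3nc(-c4cccc(O)c4)oc23)cc(OC)c1OC` differs from compound 1 by hydroxy in place of hydrogen on an aromatic carbon. The step that bears on it most is a 9.7-fold lower number from compound 1 to compound 2 (0.99 log units; beyond the scatter), where a different group entered at the same place; the other placement gave an at least 1.2-fold higher number from compound 1 to compound 3 (0.09 log units; that floor lies within the scatter), and between the two bromo compounds the step is an at least 11-fold higher number from compound 2 to compound 3 (1.07 log units; beyond the scatter). A group entering at this place can thus bring a modest drop, but a hydroxy is not a bromo, so a smaller gain is expected. Compound 4 is estimated at 8000 nM, with a range from 2000 nM to 25000 nM, meaning an expected step of a 2.5-fold lower number from compound 1 to compound 4 (0.40 log units; beyond the scatter).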

Compound 4, half-maximal inhibitory concentration: 2000 nM
Estimate against measurement, compound 4: 4.0-fold (0.60 log units) above, and the stated range covers the measured number.
By their numbers in this assay, from the lowest: compounds 4 and 2 (each within the scatter of the next); then compound 1. At a limit, above all of these: compound 3.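

Hydroxy at this place, meta to a large group, brings a 10-fold lower number from compound 1 to compound 4 (1.01 log units; beyond the scatter), and trading bromo for hydroxy gives a 1.1-fold lower number from compound 2 to compound 4 (0.02 log units; within the scatter), so the gain is no longer tied to bromo and the two groups cannot be told apart. Moving to the other placement matters as well, with an at least 12-fold lower number from compound 3 to compound 4 (1.09 log units; beyond the scatter). Compound 3 stands only at a limit of the assay: the limit of > 25000 nM in this assay, at which 1 of the 4 values shown sits.

From the compounds shown here alone, how an amine or a carboxylic acid would fare at this place stays open. So does the cause of the gain, which these numbers cannot explain.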